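The source may hold more compounds than are shown below. What is called first, only, known or untested is meant among the compounds shown, and "the series" means these compounds.

Compound 1 `O=c1[nH]c2ccc(Cl)cc2c(-c2ccccc2Cl)c1CCO` in an ADME assay on HepG2 2.2.15 cells (Homo sapiens) for cytotoxicity; a lower number here means that less compound is tolerated, a higher number that more compound is tolerated: 380000 nM
Compound 2 `COc1cccc(/C=C/C(=O)OCCc2c(-c3ccccc3Cl)c3cc(Cl)ccc3[nH]c2=O)c1` in this assay: > 1300000 nM

Among the measured compounds shown here, compound 1 is the only measured compound with a true number, 380000 nM. Compound 2 has no number, and its > 1300000 nM is only a limit of this assay. It stands at the limit of > 1300000 nM in this assay, at which 1 of the 2 values shown sits.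

The next compound is compound 3 `C/C=C/C=C/C(=O)OCCc1c(-c2ccccc2Cl)c2cc(Cl)ccc2[nH]c1=O`, and it keeps everything in compound 2 except one group. The change is prop-1-en-1-yl in place of 3-methoxyphenyl on a double-bonded chain carbon bound to a double-bonded chain carbon. In words, prop-1-en-1-yl replaces 3-methoxyphenyl on a double-bonded chain carbon bound to a double-bonded chain carbon. Cut one bond further out, 2-(3-methoxyphenyl)ethenyl becomes penta-1,3-dien-1-yl.

For the measured compounds named here, no step between measured compounds bears on this change, so the expectation is loose. A modest downward step in this assay is expected, possibly none beyond the scatter. The lower end of the range is anchored on compound 1 at 380000 nM. The expected change is an at least 1.4-fold lower number from compound 2 to compound 3 (0.15 log units; that floor lies within the scatter). For compound 3 the estimated value is 900000 nM, with an expected range of 350000 nM to 1800000 nM.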

Compound 3, half-maximal cytotoxic concentration: 440000 nM
The estimate for compound 3 lay 2.0-fold (0.31 log units) above the measured number; the range from low to high includes it.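

In this assay, replacing 3-methoxyphenyl with prop-1-en-1-yl on a double-bonded chain carbon bound to a double-bonded chain carbon gives an at least 2.9-fold lower number from compound 2 to compound 3 (0.47 log units; beyond the scatter); this position therefore responds to the group it carries. The step has only a floor, not a full size, and it rests on a limit of the assay for compound 2: the limit of > 1300000 nM in this assay, at which 1 of the 3 values shown sits. Placing (penta-1,3-dien-1-yl)carbonyl in place of hydrogen on an oxygen on a saturated carbon gives a 1.2-fold higher number from compound 1 to compound 3 (0.06 log units; within the scatter), so the ester link alone does not bring the higher tolerance, and among these three compounds only the 2-(3-methoxyphenyl)ethenyl ester reaches the limit.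

From the compounds shown here alone, the true number behind the limit remains open, as does the question of whether the aromatic ring or its methoxy group accounts for the step, which an unsubstituted phenyl or a 4-methoxyphenyl in the same place would help to separate. Also open, going by these compounds, is whether a saturated chain such as pentyl behaves like penta-1,3-dien-1-yl, and whether an amide link in place of the ester keeps the same tolerance.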